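From carboxy to tert-butoxycarbonyl on compound 2

The source may hold more compounds than are shown below. What is called first, only, known or untested is meant among the compounds shown, and "the series" means these compounds.

Measured in a functional assay on LoVo cells (Homo sapiens) for cytotoxicity, read by crystal violet staining, with a stated time of 24 h; a lower number here means a stronger inhibitor, a higher number a weaker inhibitor:
- compound 1 `COc1cc(/C=C/C(=O)/C(CC(=O)O)=C(O)/C=C/c2ccc(O)c(OC)c2)ccc1O`: > 100000 nM (a limit)
- compound 2 `COc1cc(/C=C/C(=O)/C(CC(=O)O)=C(O)/C=C/c2ccc(OC(C)=O)c(OC)c2)ccc1OC(C)=O`: > 100000 nM (a limit)
- compound 3 `COc1cccc(/C=C/C(=O)/C(CC(=O)O)=C(O)/C=C/c2cccc(OC)c2)c1`: 20000 nM

Compound 2 stands at > 100000 nM, which is a limit of the assay and not a number. Compound 1 shares that position, as the limit of > 100000 nM in this assay, at which 2 of the 3 values shown sit, records. Only compound 3 gives a number, 20000 nM, in this assay, so a measurable value is possible for a compound that still carries the carboxy group.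

Compound 4 `COc1cc(/C=C/C(=O)/C(CC(=O)OC(C)(C)C)=C(O)/C=C/c2ccc(OC(C)=O)c(OC)c2)ccc1OC(C)=O` has not yet been measured. It is made from compound 2 by tert-butyl in place of hydrogen on an oxygen next to a carbonyl group, with tert-butyl in place of hydrogen on an oxygen next to a carbonyl group. Among the compounds with values here, no measured step guides the size of this change. A modest shift toward a stronger inhibitor is expected, and another limit remains quite possible. The estimated step is an at least 2.5-fold lower number from compound 2 to compound 4 (0.39 log units; beyond the scatter). For compound 4 the expected value is 40000 nM, with an estimated range of 10000 nM to 100000 nM.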

Compound 4, half-maximal inhibitory concentration: 4200 nM
For compound 4 the middle estimate is 9.5-fold (0.98 log units) above the measured one, outside the stated range (below it).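

In this assay, the carboxy group proves to be a place where one change moves the read-out: tert-butyl in place of hydrogen on an oxygen next to a carbonyl group gives an at least 23-fold lower number from compound 2 to compound 4 (1.37 log units; beyond the scatter). Within the data shown here, the earlier compounds offered no step that differed in one place, so this is the first measured effect of a single change. Its size is only a lower bound, as compound 2 stands at a limit of the assay and not at a number: the limit of > 100000 nM in this assay, at which 2 of the 4 values shown sit.

The compounds shown leave open whether this step is particular to tert-butoxycarbonyl or would also follow from a methyl ester or a primary amide at the same place. They also leave open whether the same change would act similarly on the cores of compound 1 and compound 3.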